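The source may report more compounds than this note shows. Statements on the series, on what has been measured and on what is new or still open speak of the compounds shown alone.

In a physicochemical assay for solubility, at pH 6.8 (a higher number here means a more soluble compound, a lower number a less soluble compound), compound 1 (`CN(C)Cc1ccc(-c2cnc(N)c(C(=O)NC[C@@](C)(O)C(F)(F)F)n2)cc1`) reads 510000 nM and compound 2 (`CN(C)Cc1ccc(-c2cnc(N)c(C(=O)NC3CCC(O)CC3)n2)cc1`) reads 850000 nM on the same scale. Within the data shown here, the only measured step, a 1.7-fold higher number from compound 1 to compound 2 (0.22 log units; within the scatter) (within the scatter), leaves compound 2 level with compound 1. Compound 3 (`CN(C)Cc1ccc(-c2cnc(N)c(C(=O)NCC(O)C(F)(F)F)n2)cc1`) carries 3,3,3-trifluoro-2-hydroxypropyl in place of 4-hydroxycyclohexyl on an amide-type nitrogen and keeps the rest of compound 2 unchanged. Among the measured compounds shown here, compound 1 carries the related 2-hydroxy-2-(trifluoromethyl)propyl at that place, so the step of a 1.7-fold higher number from compound 1 to compound 2 (0.22 log units; within the scatter) is the one guide available, and it points to no change beyond the scatter in this assay for this exchange. The expected step is a 1.5-fold lower number from compound 2 to compound 3 (0.19 log units; within the scatter) and stays within the scatter. Compound 3 is estimated at 550000 nM with a range from 220000 nM to 1100000 nM as its expected span.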

Compound 3, solubility: 880000 nM
Estimate against measurement, compound 3: 1.6-fold (0.20 log units) below; low and high end bracket the measured number.
By their numbers in this assay, from the lowest: compounds 1, 2 and 3 (each within the scatter of the next).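

In this assay, putting the open-chain 3,3,3-trifluoro-2-hydroxypropyl in place of the ring of 4-hydroxycyclohexyl on the amide-type nitrogen gives a 1.0-fold higher number from compound 2 to compound 3 (0.02 log units; within the scatter), so at this place the ring and the fluorinated chain cannot be told apart in this read-out. The smaller exchange within the fluorinated chains, 2,2,2-trifluoro-1-hydroxyethyl in place of 1-hydroxy-1-(trifluoromethyl)ethyl on the saturated chain carbon, gives a 1.7-fold higher number from compound 1 to compound 3 (0.24 log units; within the scatter), and so all three compounds now stand level with one another. Nothing available bears on why these exchanges leave the reading level.

All three groups shown carry a hydroxyl, so the compounds leave open how an amine or a carboxylic acid at this place would read. They also leave open whether a longer chain or a ring bearing fluorine would stay level with compound 2 and compound 3.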